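Working notes: from compound 3 to the untested compound 4

The source may hold more compounds than are shown below. What is called first, only, known or untested is meant among the compounds shown, and "the series" means these compounds.

Measured in an assay on CHO cells for displacement of a labelled ligand from 5-hydroxytryptamine receptor 1B (Homo sapiens) (a lower number here means a stronger inhibitor, a higher number a weaker inhibitor), so far:
- compound 1 `CN(Cc1ccc(S(C)(=O)=O)cc1)C1CCN(CCCc2c[nH]c3ccc(-n4cnnc4)cc23)CC1` gives 140 nM
- compound 2 `CC(C)=CCN(C)C1CCN(CCCc2c[nH]c3ccc(-n4cnnc4)cc23)CC1` gives 41 nM
- compound 3 `CN(Cc1ccsc1)C1CCN(CCCc2c[nH]c3ccc(-n4cnnc4)cc23)CC1` gives 35 nM

Compound 3 carries the lowest number of the three, but compound 2 lies within the scatter of it; only compound 1 stands clearly apart, as a 4.0-fold lower number from compound 1 to compound 3 (0.60 log units; beyond the scatter) shows. Compound 4 `CC(=O)Nc1ccc(CN(C)C2CCN(CCCc3c[nH]c4ccc(-n5cnnc5)cc34)CC2)cc1` differs by 4-acetamidophenyl in place of thiophen-3-yl on a saturated chain carbon bound to an amine nitrogen. Among the measured compounds shown here, the steps that bear on this are a 3.4-fold lower number from compound 1 to compound 2 (0.53 log units; beyond the scatter) and a 4.0-fold lower number from compound 1 to compound 3 (0.60 log units; beyond the scatter): both replacements of the six-membered ring of compound 1 gave modest lower numbers. Compound 4 returns to a six-membered ring bearing a group in the 4-position, so a modest rise toward the number of compound 1 is expected, a 2.9-fold higher number from compound 3 to compound 4 (0.46 log units; beyond the scatter). Compound 4 is estimated at 100 nM, with a range of 40 nM to 250 nM.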

Compound 4, half-maximal inhibitory concentration: 100 nM
Beside the measured number, compound 4's estimate shows no gap at the digits printed, and the stated range covers the measured number.
By their numbers in this assay, from the lowest: compounds 3 and 2 (each within the scatter of the next); then compounds 4 and 1 (each within the scatter of the next).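

On a saturated chain carbon bound to an amine nitrogen, 4-acetamidophenyl in place of thiophen-3-yl gives a modest step (a 2.9-fold higher number from compound 3 to compound 4 (0.46 log units; beyond the scatter)) in this assay, and 4-acetamidophenyl in place of 2-methylprop-1-en-1-yl gives another (a 2.4-fold higher number from compound 2 to compound 4 (0.39 log units; beyond the scatter)). Acetamido in place of methylsulfonyl on an aromatic carbon stays within the scatter (a 1.4-fold lower number from compound 1 to compound 4 (0.15 log units; within the scatter)), so the two substituted benzyl compounds, compound 1 and compound 4, group together, clear of compound 2 and compound 3. No measurement on hand explains these steps.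

Still open, as far as these compounds go, is whether plain benzyl, or a benzyl carrying an amine or a carboxylic acid, would group with compound 1 and compound 4 or with compound 2 and compound 3.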